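Aryl group variation on the saturated ring carbon

This account rests on a few compounds, and the source may have more. Where it says the series, first, only, none or still open, it means among the compounds named here.

Measured so far, in a functional assay, with a stated time of 20 min, tested at 20 uM; a lower number here means a weaker effect, a higher number a stronger effect of the compound at the concentration tested:
compound 1 `COc1cc(/C=C/C(=O)C2=C(/C=C/c3ccc(O)c(OC)c3)NC(=O)NC2c2ccc(O)cc2)ccc1O` gives 84.6%
compound 2 `COc1cc(/C=C/C(=O)C2=C(/C=C/c3ccc(O)c(OC)c3)NC(=O)NC2c2ccc(N(C)C)cc2)ccc1O` gives 48%

Compound 2 stands at the lower of the two numbers; its nearest neighbour is compound 1, and the step between them was a number 36.6 percentage points lower from compound 1 to compound 2 (beyond the scatter), a change of dimethylamino in place of hydroxy on an aromatic carbon. Compound 3 `COc1cc(/C=C/C(=O)C2=C(/C=C/c3ccc(O)c(OC)c3)NC(=O)NC2c2ccccc2Cl)ccc1O` carries the change (2-chlorophenyl in place of 4-(dimethylamino)phenyl on a saturated ring carbon). Within the data shown here, no measured step involves a 2-chlorophenyl group, so the earlier step shows only that changing this aryl group can move this assay by a large amount, without telling the direction. Compound 3 is therefore expected at 62%, within 30% to 90%. This estimate means an expected step of a number 14 percentage points higher from compound 2 to compound 3 (beyond the scatter).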

Compound 3, a percentage reported as activity, at one concentration (the size of the read-out at that concentration, not a potency): 46%
Compound 3: middle estimate off by 16 percentage points, on the high side; low and high end bracket the measured number.
By their numbers in this assay, from the lowest: compounds 3 and 2 (each within the scatter of the next); then compound 1.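

In this assay, the aryl group on the saturated ring carbon can change from 4-(dimethylamino)phenyl to 2-chlorophenyl without a readable effect (a number 2 percentage points lower from compound 2 to compound 3 (within the scatter)). The 4-hydroxyphenyl group of compound 1 now stands apart from two different replacements, since the step to the 2-chlorophenyl group (a number 38.6 percentage points lower from compound 1 to compound 3 (beyond the scatter)) is also large and beyond the scatter. No independent measurement bears on the reason for this.

On these data alone, it remains open whether the higher number depends on the hydroxy group itself or on where it sits on the aryl ring. A 2-hydroxyphenyl, 4-chlorophenyl or unsubstituted phenyl group would separate these readings.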